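Methyl in place of methoxy on compound 2

The source may report more compounds than this note shows. Statements on the series, on what has been measured and on what is new or still open speak of the compounds shown alone.

In an ADME assay on Caco-2 cells (Homo sapiens) for permeability, read by LC-MS, with a stated time of 2 h (on this read-out higher numbers stand for higher permeability and lower numbers for lower permeability), compound 1 `COc1cc(CN(CC(C)C)C(CC(=O)O)c2ccc(Cl)c(Cl)c2)ccc1OCCN1C(=O)CCC1=O` gives 7 nm/s and compound 2 `COc1cc(CN(CC(C)C)C(CC(=O)O)c2ccc(Cl)c(F)c2)ccc1OCCN1C(=O)CCC1=O` gives 5.88 nm/s. Among the compounds with values here, these two numbers lie within the scatter of each other, and compound 1 is the only other measured compound against which compound 2 can be placed. Compound 3 `Cc1cc(CN(CC(C)C)C(CC(=O)O)c2ccc(Cl)c(F)c2)ccc1OCCN1C(=O)CCC1=O` is the next compound to read. It carries methyl in place of methoxy on an aromatic carbon, ortho to a 2-(2,5-dioxopyrrolidin-1-yl)ethoxy group: methyl in place of methoxy on an aromatic carbon. Within the data shown here, the only measured step is a 1.2-fold lower number from compound 1 to compound 2 (0.08 log units; within the scatter), for fluoro in place of chloro on an aromatic carbon. Among the measured compounds shown here, that step involves different groups, so it bears on the new change only indirectly, and no measured step covers an exchange of methoxy for methyl. On this thin basis, no step beyond the scatter is expected in this assay, and neither direction is favoured. The expected step is a 1.1-fold higher number from compound 2 to compound 3 (0.04 log units; within the scatter). For compound 3 the estimated value is 6.5 nm/s, with an expected range of 3 nm/s to 14 nm/s.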

Compound 3, apparent permeability: 37.8 nm/s
Beside the measured number, compound 3's estimate is 5.8-fold (0.76 log units) below it; the measured number lies above the stated range.
By their numbers in this assay, from the lowest: compounds 2 and 1 (each within the scatter of the next); then compound 3.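

In this assay, within the data shown here, the aromatic carbon ortho to a 2-(2,5-dioxopyrrolidin-1-yl)ethoxy group is the first place where a single exchange takes the read-out beyond the scatter: methyl in place of methoxy gives a 6.4-fold higher number from compound 2 to compound 3 (0.81 log units; beyond the scatter). Among these compounds, the only earlier step, fluoro in place of chloro, gave a 1.2-fold lower number from compound 1 to compound 2 (0.08 log units; within the scatter) and stayed within the scatter, so the series now holds one exchange that leaves the number within the scatter and one that does not. No measurement at hand accounts for the step at this position.

Only one exchange is shown at this position, so it remains open how a hydrogen, an ethyl, a chloro or a nitrile on the same aromatic carbon would read, and a single pair cannot separate the loss of methoxy from the arrival of methyl. From the compounds shown here alone, it also remains open whether methyl in place of methoxy would give a step of similar size on the core of compound 1, which carries chloro where compound 2 carries fluoro.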